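A few compounds are considered here, and "the series" means these few. Any claim that something is new, unique, unknown or untested is made for them only; others in the source may bear on it.

Measured so far in an assay on BaF3 cells for inhibition of thrombopoietin receptor (Homo sapiens), tested at 150 nM; on this read-out lower numbers stand for a weaker effect and higher numbers for a stronger effect at the one concentration tested:
compound 1 `C/C(NNC(=S)N1CCc2cc(C(=O)O)ccc21)=C1/C(=O)N(c2ccc3c(c2)CCC3)c2ccccc21` gives 14.3%
compound 2 `C/C(NNC(=S)N1CCc2cc(C(=O)O)ccc21)=C1/C(=O)N(c2ccc(C)c(C)c2)c2ccccc21` gives 72.4%
compound 3 `C/C(NNC(=S)N1CCc2cc(C(=O)O)ccc21)=C1/C(=O)N(c2ccc3c(c2)CCC3)c2ccc(F)cc21` gives 3.2%

Compound 3 stands lowest of the three; compound 1 sits above it and compound 2 far above. Compound 4 `C/C(NNC(=S)N1CCc2cc(C(=O)O)ccc21)=C1/C(=O)N(c2ccc(C)cc2)c2ccc(F)cc21` differs from compound 3 in one place: 4-methylphenyl in place of 2,3-dihydro-1H-inden-5-yl on an amide-type nitrogen in a ring. Among the compounds with values here, two measured steps bear on it. The same kind of exchange on the amide-type nitrogen, with 3,4-dimethylphenyl entering, gave a number 58.1 percentage points higher from compound 1 to compound 2 (beyond the scatter); the fluoro on the aromatic carbon that compound 3 and compound 4 share gave a number 11.1 percentage points lower from compound 1 to compound 3 (beyond the scatter). A large rise is therefore expected for compound 4 in this assay, though 4-methylphenyl is not 3,4-dimethylphenyl, so the expected step is taken as a number 36.8 percentage points higher from compound 3 to compound 4 (beyond the scatter). Compound 4 is thus estimated at 40%, in the range 10% to 70%.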

Compound 4, a percentage reported as inhibition, at one concentration (the size of the read-out at that concentration, not a potency): 78.1%
For compound 4 the middle estimate is 38.1 percentage points below the measured one; the measured number lies above the stated range.
By their numbers in this assay, from the lowest: compound 3; then compound 1; then compounds 2 and 4 (each within the scatter of the next).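

In this assay, the exchange on the amide-type nitrogen, made here on the fluoro-bearing core, gives a number 74.9 percentage points higher from compound 3 to compound 4 (beyond the scatter). The large gain on leaving 2,3-dihydro-1H-inden-5-yl therefore appears with the fluoro present as well as without it, and a single methyl on the phenyl ring is enough to produce it. Still open, going by these compounds, is what a plain phenyl, 4-methoxyphenyl or 4-aminophenyl would give on this nitrogen, and what 4-methylphenyl would give on the core without the fluoro. No measurement available here accounts for the size of this step.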